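The source may report more compounds than this note shows. Statements on the series, on what has been measured and on what is new or still open speak of the compounds shown alone.

Notes on the series in a functional assay on HCT-116 cells (Homo sapiens), read by MTT assay, with a stated time of 72 h; on this read-out lower numbers stand for stronger inhibition and higher numbers for weaker inhibition.

Compound 1 `CN(C)c1ncnc2c1c(-c1ccoc1)cn2[C@@H]1O[C@H](CO)[C@@H](O)[C@H]1O` carries a furan-3-yl group on its core. In this assay compound 1 reaches only > 20000 nM, which is a limit of the assay and not a number. Compound 2 `CN(C)c1ncnc2c1c(-c1cc3ccccc3o1)cn2[C@@H]1O[C@H](CO)[C@@H](O)[C@H]1O` differs from compound 1 by 1-benzofuran-2-yl in place of furan-3-yl on an aromatic carbon. In this assay compound 2 likewise returns > 20000 nM, again a limit rather than a number. The step that the two limits leave unreadable from compound 1 to compound 2 cannot be sized, since both ends sit on (the limit of > 20000 nM in this assay, at which 3 of the 3 values shown sit).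

Compound 3 `Nc1nc(N)c2c(-c3ccoc3)cn([C@@H]3O[C@H](CO)[C@@H](O)[C@H]3O)c2n1` has a different core; the difference between the two cores is not broken down here. In this assay compound 3 also gives > 20000 nM, a limit of the assay.

Compound 4 `Nc1nc(N)c2c(-c3cc4ccccc4o3)cn([C@@H]3O[C@H](CO)[C@@H](O)[C@H]3O)c2n1` has not yet been measured. It differs from compound 3 by 1-benzofuran-2-yl in place of furan-3-yl on an aromatic carbon, the same change, at the same place, as from compound 1 to compound 2. The expected step is a step that the limit leaves unreadable from compound 3 to compound 4, worded as an expectation only. It rests on compound 3 sitting at > 20000 nM. It rests further on the earlier pair both standing on (the limit of > 20000 nM in this assay, at which 3 of the 3 values shown sit). Compound 4 is therefore estimated at 30000 nM, with a range from 10000 nM to 100000 nM, most probably reported once more only as a limit.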

Compound 4, half-maximal inhibitory concentration: > 20000 nM
Compound 4: no number, only a limit; the forecaster's own chance of this, stated with the estimate: 85%; the middle value is on the limit's open side.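

No step can be read from compound 3 to compound 4 in this assay, because both compounds give a limit of the assay and not a number: the limit of > 20000 nM in this assay, at which 4 of the 4 values shown sit. The compounds shown leave open whether 1-benzofuran-2-yl and furan-3-yl differ at all on either core, and how far each of the four compounds lies beyond that limit.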